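From fluoro to methyl: estimating compound 3

This account rests on a few compounds, and the source may have more. Where it says the series, first, only, none or still open, it means among the compounds named here.

Measured so far in a functional assay on RAW264.7 cells (Mus musculus) for inhibition; a higher number here means a weaker inhibitor, a lower number a stronger inhibitor:
Compound 1 `Cc1ccc(S(=O)(=O)NC(=O)c2cccnc2)cc1`: 8800 nM
Compound 2 `O=C(NS(=O)(=O)c1ccc(F)cc1)c1ccccn1`: 3300 nM

Of these two numbers, compound 2 holds the lower at 3300 nM, which makes it the stronger inhibitor of the pair. Compound 1 stands higher at 8800 nM, and this gap lies beyond the usual scatter of repeated measurements. The two compounds differ in more than one place, so the gap cannot be tied to any single change.

Compound 3 `Cc1ccc(S(=O)(=O)NC(=O)c2ccccn2)cc1` has not yet been measured. It keeps the core of compound 2 but has methyl in place of fluoro on an aromatic carbon, para to a large group (methyl in place of fluoro on an aromatic carbon). Within the data shown here, no measured pair shows this change alone, so the data give no direct guide to its size.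

One heavy atom replaces one other, so no step beyond the scatter is expected in this assay. There is a slight lean towards a higher number: compound 1, which also carries methyl, gives 8800 nM. The expected step is small, a 1.4-fold higher number from compound 2 to compound 3 (0.13 log units; within the scatter). For compound 3 the estimated value is 4500 nM, with an expected range of 1500 nM to 13000 nM.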

Compound 3, half-maximal inhibitory concentration: 5900 nM
Beside the measured number, compound 3's estimate is 1.3-fold (0.12 log units) below it; low and high end bracket the measured number.
By their numbers in this assay, from the lowest: compounds 2, 3 and 1 (each within the scatter of the next, the first and the last beyond it).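

Among these compounds, compound 3 gives the first pair that shows methyl in place of fluoro on an aromatic carbon, para to a large group, on its own: in this assay the change is a 1.8-fold higher number from compound 2 to compound 3 (0.25 log units; within the scatter) and does not clear the scatter of repeated measurements. Among the compounds shown here, it also gives the first pair that isolates pyridin-2-yl in place of pyridin-3-yl on a carbonyl carbon, a change of a 1.5-fold lower number from compound 1 to compound 3 (0.17 log units; within the scatter) that likewise stays within the scatter, so neither change taken alone gives a step beyond the scatter, even though compound 1 and compound 2, which differ in both places, lie beyond the scatter of each other. For the compounds shown here, nothing measured so far offers an explanation for the size of either step.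

From the compounds shown here alone, only fluoro and methyl have been seen at this aromatic carbon, so it remains open whether a group such as trifluoromethyl, an amine or a carboxylic acid in the same place would give a step beyond the scatter. The same question stands for the group on the carbonyl carbon, where only pyridin-2-yl and pyridin-3-yl appear and a phenyl ring or pyridin-4-yl could still behave differently.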